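Swapping a Methyl for Methoxyphenyl in a Kinase Inhibition Assay

The compounds below may be only part of what the source reports. "The series", "measured", "known", "first", "only" and "open" are said of these compounds alone.

Three compounds sharing a fused two-ring core were tested in an assay on isolated protein for inhibition of ribosomal protein S6 kinase alpha-5 (Homo sapiens), read by mobility shift assay, tested at 30 uM; on this read-out lower numbers stand for less inhibition and higher numbers for more inhibition at the one concentration tested (going by the name of the read-out). Compound 1 `Cc1cc2c(c(N)nn2C)c(=O)[nH]1` gives 4% in this assay. Compound 2 `CC(=O)Nc1nn(C)c2cc(-c3ccccc3)[nH]c(=O)c12` gives 3% in this assay. Compound 3 `Cc1cc2nn(-c3ccccc3)c(N)c2c(=O)[nH]1` gives 4% in this assay, the same number as compound 1 at the digits shown, and separated from compound 2 only by a gap that lies within the scatter of repeated measurements. All three numbers are level with one another within the scatter at the single concentration tested.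

Compound 4 `COc1ccc(-c2cc3nn(-c4ccccc4)c(N)c3c(=O)[nH]2)cc1` has not yet been measured. It differs from compound 3 in one place: 4-methoxyphenyl in place of methyl on an aromatic carbon. Among the compounds with values here, no pair of measured compounds isolates this exact change, but compound 2 already carries a phenyl group and gives 3%, which does not differ beyond the scatter from the other two. On that basis the step of a number 1 percentage points higher from compound 3 to compound 4 (within the scatter) is expected to stay within the scatter, with no clear direction. Compound 4 is accordingly estimated to give 5% in this assay, with a likely range from -5% to 20%.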

Compound 4, a percentage reported as inhibition, at one concentration (the size of the read-out at that concentration, not a potency): 6%
Beside the measured number, compound 4's estimate is 1 percentage points below it; the measured number falls inside the stated range.
By their numbers in this assay, from the lowest: compounds 2, 1, 3 and 4 (each within the scatter of the next).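

In this assay, putting 4-methoxyphenyl in place of methyl on this aromatic carbon gives a number 2 percentage points higher from compound 3 to compound 4 (within the scatter), so the two compounds cannot be told apart. This shows that the position, on an aromatic carbon next to the ring nitrogen, can carry a group of 8 heavy atoms with a six-membered aromatic ring and a hydrogen-bond acceptor, instead of a single carbon, without the read-out moving beyond the scatter in either direction. Nothing measured here offers an explanation for this result.

From the compounds shown here alone, it remains open whether a different kind of group at this carbon, such as an amine, a carboxylic acid or a longer alkyl chain, would move the number in this assay beyond the scatter. Going by these compounds, the effect of a change at this carbon also remains unknown for any other substituent on the shared core.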